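Swapping tert-butyl for trifluoromethyl on compound 1

A few compounds are considered here, and "the series" means these few. Any claim that something is new, unique, unknown or untested is made for them only; others in the source may bear on it.

In an ADME assay on HEK293 cells (Homo sapiens) for cytotoxicity, with a stated time of 72 h (a lower number here means that less compound is needed, a higher number that more compound is needed for the effect), compound 1 (`Cc1cc(NC(=O)Nc2ccc(C(C)(C)C)cc2)c2ccccc2n1`) gives > 25000 nM as a limit, not a number. Compound 2 (`Cc1cc(NC(=O)Nc2cccc([N+](=O)[O-])c2)c2ccccc2n1`) also gives > 25000 nM as a limit. Compound 3 (`Cc1cc(NC(=O)Nc2ccc(F)c(F)c2)c2ccccc2n1`) likewise gives > 25000 nM as a limit. Within the data shown here, compound 1 therefore has no exact number, and the series so far reads as one line (the limit of > 25000 nM in this assay, at which 3 of the 3 values shown sit).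

Compound 4 (`Cc1cc(NC(=O)Nc2ccc(C(F)(F)F)cc2)c2ccccc2n1`) has not yet been measured. It carries trifluoromethyl in place of tert-butyl on an aromatic carbon of the core of compound 1 (trifluoromethyl in place of tert-butyl on an aromatic carbon). Among the measured compounds shown here, no step between measured compounds exists to size this change in this assay directly. With compound 1 sitting at the shared limit (the limit of > 25000 nM in this assay, at which 3 of the 3 values shown sit), no step beyond the scatter is expected, in either direction. The expected step (a number no higher from compound 1 to compound 4 (the limit leaves the size open)) is an estimate only, and the result may well come back as a limit again. For compound 4 the estimated value is 25000 nM within an expected range of 12000 nM to 50000 nM in this test.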

Compound 4, half-maximal effective concentration: 25000 nM
Beside the measured number, compound 4's estimate shows no gap at the digits printed; the range from low to high includes it.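

In this assay compound 4 gives 25000 nM, the only exact number among the compounds shown, so a compound with trifluoromethyl at this place can be read on the scale of the test itself. Compound 1 gives > 25000 nM, which is a limit and not a number. Swapping tert-butyl for trifluoromethyl can therefore be described only as a number no higher from compound 1 to compound 4 (the limit leaves the size open), so the data fix its direction at most and cannot show whether the change matters.

The rest of the series gives little to compare with: the limit of > 25000 nM in this assay, at which 3 of the 4 values shown sit.
From the compounds shown here alone, whether an amine or a carboxylic acid on the same aromatic carbon would give a clearly lower number in this assay stays open, and so does whether a longer chain there would.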